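A few compounds are considered here, and "the series" means these few. Any claim that something is new, unique, unknown or untested is made for them only; others in the source may bear on it.

Measured compounds, with values in a functional assay on Bel-7402 cells (Homo sapiens) for cytotoxicity, read by MTT assay; on this read-out lower numbers stand for stronger inhibition and higher numbers for weaker inhibition:
- compound 1 `Cc1ccccc1Nc1nc(C)c(C(=O)/C=C/c2ccccc2)s1`: compound 1 gives > 25000 nM, which is a limit of the assay and not a number.
- compound 2 `Cc1nc(Nc2ccccc2)sc1C(=O)/C=C/c1ccccc1Cl`: compound 2 gives > 25000 nM, again a limit.
- compound 3 `Cc1ccc(Nc2nc(C)c(C(=O)/C=C/c3ccccc3Cl)s2)cc1`: compound 3 gives > 25000 nM, also a limit.

Compound 3 therefore stands only at a limit in this assay, with no number of its own; the same holds for the other two values shown, all of them sitting together at the limit of > 25000 nM in this assay, at which 3 of the 3 values shown sit. Going by the values given here, the one single-point step among the measured compounds, a step that the two limits leave unreadable from compound 2 to compound 3, is a methyl in place of hydrogen on an aromatic carbon, and its size cannot be read because both ends are limits.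

Compound 4 `Cc1ccccc1Nc1nc(C)c(C(=O)/C=C/c2ccccc2Cl)s1` is not yet measured. It differs from compound 3 by 2-methylphenyl in place of 4-methylphenyl on a nitrogen on an aromatic ring. Compound 1 already carries the 2-methylphenyl group on the same nitrogen and gives only a limit, and compound 2 and compound 3 carry the same 2-chlorophenyl part of compound 4 and also give only limits. Among the compounds with values here, no measured step bears readably on this change, so no step beyond the scatter can be expected in either direction; the step from compound 3 to compound 4 is estimated as a step that the limit leaves unreadable from compound 3 to compound 4. On that basis compound 4 is expected to give about 40000 nM in this assay, within 15000 nM to 200000 nM, most likely reported again only as a limit.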

Compound 4, half-maximal inhibitory concentration: > 25000 nM
Compound 4 was reported as a limit; the forecaster's own chance of this, stated with the estimate: 85%; the middle value does not contradict the limit.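

In this assay compound 4 gives > 25000 nM, a limit of the assay and not a number. No new step can be read, as the steps joining compound 1, compound 2 and compound 3 to compound 4 all run between limits. The series sits together: the limit of > 25000 nM in this assay, at which 4 of the 4 values shown sit.

The compounds shown leave open whether any of these single changes moves the read-out at all.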